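The compounds below may be only part of what the source reports. "The series", "measured", "known", "first", "only" and "open" are said of these compounds alone.

Measured so far in a functional assay for inhibition, with Homo sapiens as the target; a lower number here means a stronger inhibitor, a higher number a weaker inhibitor: compound 1 `COc1ccc(N(C)c2nccc(-c3cccnc3)n2)cc1`, compound 2 `COc1ccc(Nc2nccc(-c3cccnc3)n2)cc1`, compound 3 `c1ccc(Nc2nccc(-c3ccncc3)n2)cc1`.

Compound 2 gives 1700 nM. Compound 3 gives 900 nM, the lowest of the two numbers, although the gap to compound 2 is within the scatter. Compound 1 gives only a limit, > 24000 nM, that is the limit of > 24000 nM in this assay, at which 1 of the 3 values shown sits. Compound 1 differs from compound 2 by methyl in place of hydrogen on a nitrogen on an aromatic ring, and this change brought an at least 14-fold higher number from compound 2 to compound 1 (1.14 log units; beyond the scatter). Compound 4 `CN(c1ccccc1)c1nccc(-c2ccncc2)n1`, still unmeasured, differs from compound 3 by exactly the same change, (methyl in place of hydrogen on a nitrogen on an aromatic ring). The difference between the core of compound 2 and the core of compound 3 is not broken down here. A step of similar size is expected now, a 22-fold higher number from compound 3 to compound 4 (1.35 log units; beyond the scatter), because an at least 14-fold higher number from compound 2 to compound 1 (1.14 log units; beyond the scatter) was large. Compound 4 is therefore estimated to give about 20000 nM in this assay, quite possibly again only a limit.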

Compound 4, half-maximal inhibitory concentration: > 24000 nM
Compound 4 gave a limit, no number; the forecaster's own chance of this, stated with the estimate: 50%; at least 1.2-fold (0.07 log units) between middle value and limit.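

In this assay, methyl in place of hydrogen on a nitrogen on an aromatic ring gave an at least 26-fold higher number from compound 3 to compound 4 (1.42 log units; beyond the scatter), so the large step seen on the first core also appears on a second core. This shows that the change carries over in direction, but it does not show whether its size is the same on both cores: the same change on two cores in this assay, an at least 14-fold higher number (1.14 log units; beyond the scatter) from compound 2 to compound 1 and an at least 26-fold higher number (1.42 log units; beyond the scatter) from compound 3 to compound 4; the limit leaves it open whether they differ. Compound 4 gives a limit and not a number, as does compound 1: the limit of > 24000 nM in this assay, at which 2 of the 4 values shown sit.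

The compounds shown leave open how a longer chain such as ethyl, or an acetyl group, would act in place of that hydrogen. They also leave open whether any group there other than hydrogen can give a number instead of a limit.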